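The source may report more compounds than this note shows. Statements on the series, on what has been measured and on what is new or still open speak of the compounds shown alone.

Compound 1 `O/N=C(/Nc1cccc(Br)c1)c1ccc2occc2c1` is the starting point. In an assay on tissue (HeLa cells) for inhibition of Indoleamine 2,3-dioxygenase 1 (Homo sapiens), read by spectrophotometry (a lower number here means a stronger inhibitor, a higher number a weaker inhibitor), compound 1 gives 1100 nM, the lowest of the two numbers shown. Compound 3 `O/N=C(/Nc1cccc(-c2ccccc2)c1)c1ccc2occc2c1` gives 11900 nM in this assay. Compound 2 `O/N=C(/Nc1cccc(Oc2ccccc2)c1)c1ccc2occc2c1` reaches only the limit > 30000 nM in this assay, a boundary of the measurement rather than a number (the limit of > 30000 nM in this assay, at which 1 of the 3 values shown sits). Both changes swap the bromo on the aniline-type ring: an 11-fold higher number from compound 1 to compound 3 (1.03 log units; beyond the scatter), and an at least 27-fold higher number from compound 1 to compound 2 (1.43 log units; beyond the scatter). Between the two larger groups, an at least 2.5-fold lower number from compound 2 to compound 3 (0.40 log units; beyond the scatter).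

Compound 4 `O/N=C(/Nc1cccc(Br)c1)c1ccc2oc(-c3ccccc3)cc2c1` is not yet measured. It keeps the bromo of compound 1 and changes the shared core instead: phenyl in place of hydrogen on an aromatic carbon. Among the measured compounds shown here, no measured step alters this part of the molecule, so the steps above bear on it only loosely; they show that adding a phenyl to the other ring weakened compound 3 relative to compound 1. A modest weakening is therefore expected in this assay for compound 4, though the direction is uncertain. Compound 4 is estimated at 2000 nM, with a range from 450 nM to 9000 nM. The expected step is a 1.8-fold higher number from compound 1 to compound 4 (0.26 log units; within the scatter).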

Compound 4, half-maximal inhibitory concentration: 8600 nM
Compound 4: middle estimate off by 4.3-fold (0.63 log units), on the low side, and the stated range covers the measured number.
By their numbers in this assay, from the lowest: compound 1; then compounds 4 and 3 (each within the scatter of the next). At a limit, above all of these: compound 2.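

Adding a phenyl on the carbon next to the ring oxygen gives a 7.8-fold higher number from compound 1 to compound 4 (0.89 log units; beyond the scatter) in this assay, so the shared core, and not only the bromo-bearing ring, influences the reading. This carbon still accepts a group as large as phenyl with a measurable result, but the inhibitor is clearly weaker than compound 1. Nothing measured among these compounds explains the loss.

The compounds shown leave open whether the weakening comes with any group at this carbon or is specific to phenyl, as a methyl, an amine or a carboxylic acid there could tell. How a change at this carbon would combine with replacing the bromo on the other ring also remains unanswered.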